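This account rests on a few compounds, and the source may have more. Where it says the series, first, only, none or still open, it means among the compounds named here.

Working notes on the series. The shared core of compound 1 `Nc1ccnc2c1nc(-c1ccccc1)n2CCN1CCCCC1` is kept in compound 2 `Nc1ccnc2c1nc(-c1ccccc1)n2CCCO` and compound 3 `CCCCCn1c(-c2ccccc2)nc2c(N)ccnc21`; the three differ only at the chain on the ring nitrogen. In an assay on isolated protein for inhibition of high affinity 3',5'-cyclic-AMP phosphodiesterase 7A (Homo sapiens), read by cAMP accumulation, with a stated time of 20 min (a lower number here means a stronger inhibitor, a higher number a weaker inhibitor), compound 1 gives > 200000 nM, which is a limit of the assay. In this assay compound 2 gives > 200000 nM, again a limit. In this assay compound 3 gives > 200000 nM, also a limit and not a number. Compound 3 therefore stands nowhere readable on the numbers shown: the step from compound 1 to compound 2 is a step that the two limits leave unreadable from compound 1 to compound 2, the step from compound 1 to compound 3 is a step that the two limits leave unreadable from compound 1 to compound 3, and the step from compound 2 to compound 3 is a step that the two limits leave unreadable from compound 2 to compound 3, all unreadable because of the limit of > 200000 nM in this assay, at which 3 of the 3 values shown sit.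

Compound 4 `CCCCCn1c(-c2ccc([N+](=O)[O-])cc2)nc2c(N)ccnc21` is not yet measured. It differs from compound 3 by nitro in place of hydrogen on an aromatic carbon; the group enters on an aromatic carbon of a six-membered aromatic ring of carbon only, para to a large group. Among the compounds with values here, no measured step touches this ring, so nothing here bears on the change. The expectation for compound 4 in this assay is 300000 nM, within 50000 nM to 2000000 nM, most likely reported as a limit again; the step from compound 3 to compound 4 is thus estimated at a step that the limit leaves unreadable from compound 3 to compound 4.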

Compound 4, half-maximal inhibitory concentration: > 200000 nM
Compound 4: only a limit was reported (the forecaster's own chance of this, stated with the estimate: 80%); the middle value does not contradict the limit.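

No step can be read between compound 3 and compound 4 in this assay, because the values of both are limits and not numbers: the limit of > 200000 nM in this assay, at which 4 of the 4 values shown sit.

The compounds shown leave open how strongly any of them inhibits the enzyme, and whether nitro in place of hydrogen or a change in the chain on the ring nitrogen alters inhibition at all.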